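Chain extension in a three-compound series, one analogue untested

The source may hold more compounds than are shown below. What is called first, only, known or untested is meant among the compounds shown, and "the series" means these compounds.

Measured in a functional assay, with a stated time of 90 min; a lower number here means that less compound is needed, a higher number that more compound is needed for the effect:

compound 1 `CC(C)=NNc1nc(-c2cccc([N+](=O)[O-])c2)cs1` gives 1750000 nM
compound 2 `CCC/C(C)=N\Nc1nc(-c2cccc([N+](=O)[O-])c2)cs1` gives 1200000 nM
compound 3 `CCC/C(CC)=N\Nc1nc(-c2cccc([N+](=O)[O-])c2)cs1` gives 1250000 nM

All three numbers in this assay are high and lie within the scatter of one another. The change ethyl in place of hydrogen on a saturated chain carbon bound to a carbon with a double bond to nitrogen gave a 1.5-fold lower number from compound 1 to compound 2 (0.16 log units; within the scatter). The change methyl in place of hydrogen on a saturated chain carbon bound to a carbon with a double bond to nitrogen is not broken down here beyond its step, a 1.0-fold higher number from compound 2 to compound 3 (0.02 log units; within the scatter).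

Compound 4 `CCCCC/C(CC)=N\Nc1nc(-c2cccc([N+](=O)[O-])c2)cs1` is not yet measured. It differs from compound 3 by ethyl in place of hydrogen on a saturated chain carbon, three bonds along the chain from a carbon with a double bond to nitrogen. The same kind of change, ethyl in place of hydrogen, was made from compound 1 to compound 2, but there the place was on a saturated chain carbon bound to a carbon with a double bond to nitrogen, whereas here it is three bonds along the chain from that carbon. The two starting cores differ by a group of 7 heavy atoms (6 carbon, 1 nitrogen; no ring) in place of a group of 4 heavy atoms (3 carbon, 1 nitrogen; no ring), on a nitrogen on an aromatic ring, with a 1.4-fold lower number from compound 1 to compound 3 (0.15 log units; within the scatter).

Since the earlier ethyl step stayed within the scatter, compound 4 is expected to show a 1.3-fold lower number from compound 3 to compound 4 (0.10 log units; within the scatter) in this assay. The estimate for compound 4 is 1000000 nM, between 500000 nM and 2200000 nM.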

Compound 4, half-maximal effective concentration: 1470000 nM
Compound 4: middle estimate off by 1.5-fold (0.17 log units), on the low side; the range from low to high includes it.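

In this assay, the ethyl change on the longer chain gives a 1.2-fold higher number from compound 3 to compound 4 (0.07 log units; within the scatter), so compound 4 stays within the scatter of its parent. Set beside the earlier ethyl change, the new step does not differ from it beyond the scatter: the same change on two cores in this assay, a 1.5-fold lower number (0.16 log units; within the scatter) from compound 1 to compound 2 and a 1.2-fold higher number (0.07 log units; within the scatter) from compound 3 to compound 4, 1.7-fold (0.23 log units) apart, within the scatter of two such steps. Among these compounds, this shows only that the change leaves the number within the scatter on both cores; it does not show a shared effect of the change that carries from one core to the other, since neither step can be told apart from the scatter, and the two changes also sit at different places on the chain.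

Still open, on these data alone, is whether any group on this chain moves the number in this assay beyond the scatter, for instance an amine or a carboxylic acid at the chain end, or a much longer chain. The compounds shown also leave open whether the ethyl change would behave alike on a core that gives a much lower number.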